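The source may hold more compounds than are shown below. What is called first, only, known or untested is meant among the compounds shown, and "the series" means these compounds.

Compound 1 `CCOC(=O)c1cccc(-c2cnc(C(=O)CCc3ccc(-c4ccccc4)cc3)o2)n1` gives 3 nM in an assay for inhibition of Fatty-acid amide hydrolase 1 (Rattus norvegicus); on this read-out higher numbers stand for weaker inhibition and lower numbers for stronger inhibition.
Compound 2 `O=C(CCc1ccc(-c2ccccc2)cc1)c1ncc(-c2cccnc2)o1` gives 1.1 nM in this assay.
Compound 3 `NC(=O)c1cccc(-c2cnc(C(=O)CCc3ccc(-c4ccccc4)cc3)o2)n1` gives 1.2 nM in this assay.

Among these three, compound 1 stands highest. Its nearest neighbour is reached by the step of a 2.5-fold lower number from compound 1 to compound 3 (0.40 log units; beyond the scatter), and compound 2 sits further away again, also beyond the scatter.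

Compound 4 `N#Cc1cccc(-c2cnc(C(=O)CCc3ccc(-c4ccccc4)cc3)o2)n1` has not yet been measured in this assay. It differs from compound 1 by cyano in place of ethoxycarbonyl on an aromatic carbon. Among the measured compounds shown here, the one measured step at this place, a 2.5-fold lower number from compound 1 to compound 3 (0.40 log units; beyond the scatter), shows that replacing the ester function lowers the number modestly. The step of a 1.1-fold higher number from compound 2 to compound 3 (0.04 log units; within the scatter) shows that the carbamoyl-bearing ring and the plain pyridin-3-yl ring give numbers within the scatter of each other, so a small group at this position does not appear to cost anything. Compound 4 is therefore expected to move modestly downward from compound 1, as a 2.0-fold lower number from compound 1 to compound 4 (0.30 log units; within the scatter). The estimate for compound 4 in this assay is 1.5 nM, with a range from 0.6 nM to 4 nM.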

Compound 4, inhibition constant: 2.9 nM
Estimate against measurement, compound 4: 1.9-fold (0.29 log units) below, within the range that was stated.
By their numbers in this assay, from the lowest: compounds 2 and 3 (each within the scatter of the next); then compounds 4 and 1 (each within the scatter of the next).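

In this assay, the step of a 1.0-fold lower number from compound 1 to compound 4 (0.01 log units; within the scatter) places cyano and ethoxycarbonyl level at this carbon next to the ring nitrogen, so losing the ester does not by itself lower the number. The step of a 2.4-fold higher number from compound 3 to compound 4 (0.38 log units; beyond the scatter) separates the two smaller groups, which ties the earlier gain from the ester to carbamoyl among the groups shown, not to ester removal as such. The step of a 2.6-fold higher number from compound 2 to compound 4 (0.42 log units; beyond the scatter) adds that the 6-cyanopyridin-2-yl ring also stands apart from the pyridin-3-yl ring, so the earlier level match between compound 2 and compound 3 does not extend to every small group here.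

As far as these compounds go, it remains open whether a carboxylic acid, a methylamide or an aminomethyl group at this carbon would follow carbamoyl or cyano. Nothing shown here explains why carbamoyl and cyano differ.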